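Replacing the 4-methyl-3-nitrophenyl group of compound 3

The source may hold more compounds than are shown below. What is called first, only, known or untested is meant among the compounds shown, and "the series" means these compounds.

Measured in a functional assay on Bel-7402 cells (Homo sapiens) for cytotoxicity, read by MTT assay; a higher number here means a weaker inhibitor, a lower number a stronger inhibitor:
- compound 1 `CCn1cc(C(=O)Nc2ccccc2)c(=O)c2cc(F)c(N3CCNC(C)C3)c(F)c21`: 6000 nM
- compound 2 `CCn1cc(C(=O)Nc2cccc([N+](=O)[O-])c2)c(=O)c2cc(F)c(N3CCNC(C)C3)c(F)c21`: 1000 nM
- compound 3 `CCn1cc(C(=O)Nc2ccc(C)c([N+](=O)[O-])c2)c(=O)c2cc(F)c(N3CCNC(C)C3)c(F)c21`: 29100 nM

Compound 3 has the highest number of the three, so it is the weakest inhibitor here. Compound 4 `CCn1cc(C(=O)Nc2ccc(OC)cc2)c(=O)c2cc(F)c(N3CCNC(C)C3)c(F)c21` has 4-methoxyphenyl in place of 4-methyl-3-nitrophenyl on an amide-type nitrogen.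

Nitro alone gave a 6.0-fold lower number from compound 1 to compound 2 (0.78 log units; beyond the scatter), and adding methyl then gave a 29-fold higher number from compound 2 to compound 3 (1.46 log units; beyond the scatter). Together they amount to a 4.9-fold higher number from compound 1 to compound 3 (0.69 log units; beyond the scatter). Within the data shown here, no measured step covers methoxy. Compound 4 loses both the nitro and the methyl, so the nearest guide is the plain phenyl of compound 1 at 6000 nM. In this assay the expected step is a 4.9-fold lower number from compound 3 to compound 4 (0.69 log units; beyond the scatter), a modest one toward a lower number. The estimate for compound 4 is 6000 nM, with an expected range of 1500 nM to 24000 nM.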

Compound 4, half-maximal inhibitory concentration: 5400 nM
Estimate against measurement, compound 4: 1.1-fold (0.05 log units) above; the range from low to high includes it.
By their numbers in this assay, from the lowest: compound 2; then compounds 4 and 1 (each within the scatter of the next); then compound 3.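

In this assay there is a step of a 1.1-fold lower number from compound 1 to compound 4 (0.05 log units; within the scatter) when methoxy replaces hydrogen, so 4-methoxyphenyl cannot be told apart from plain phenyl on this amide-type nitrogen. The nitro-bearing groups fall on either side of it, with a 5.4-fold lower number from compound 3 to compound 4 (0.73 log units; beyond the scatter) and a 5.4-fold higher number from compound 2 to compound 4 (0.73 log units; beyond the scatter), so only they move the number beyond the scatter in this set. Nothing available explains these differences.

Still open, from the compounds shown here alone, is how an amine or a carboxylic acid on the phenyl group would compare with methoxy and nitro.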